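From 4-chlorobenzyl to 3-chlorobenzyl on the shared core

The compounds below may be only part of what the source reports. "The series", "measured", "known", "first", "only" and "open" are said of these compounds alone.

Among the measured compounds shown here, only two compounds have been measured so far in a functional assay on A549 cells (Homo sapiens) for cytotoxicity, read by MTT assay, with a stated time of 72 h (on this read-out lower numbers stand for stronger inhibition and higher numbers for weaker inhibition), and they sit clearly apart. Compound 2 (`CN(C)Cc1ccc2nc(NC(=O)N/N=C/c3cn(Cc4ccc(Cl)cc4)c4ccccc34)sc2c1`) gives 840 nM as the lower of the two numbers. Compound 1 (`CC1CCN(Cc2ccc3nc(NC(=O)N/N=C/c4cn(Cc5cccc(Cl)c5)c5ccccc45)sc3c2)CC1`) gives 2810 nM as the higher number, a gap beyond the usual scatter.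

Compound 3 (`CN(C)Cc1ccc2nc(NC(=O)N/N=C/c3cn(Cc4cccc(Cl)c4)c4ccccc34)sc2c1`) awaits measurement. Its change from compound 2 is 3-chlorophenyl in place of 4-chlorophenyl on a saturated chain carbon bound to an aromatic nitrogen and amounts to 3-chlorophenyl in place of 4-chlorophenyl on a saturated chain carbon bound to an aromatic nitrogen, or 4-chlorobenzyl to 3-chlorobenzyl when cut one bond further out.

For the measured compounds named here, no measured pair isolates this change. Compound 1 also carries 3-chlorobenzyl but differs from compound 2 elsewhere as well, so compound 1 at 2810 nM offers only a weak hint toward a higher number. The estimated 1.4-fold higher number from compound 2 to compound 3 (0.15 log units; within the scatter) is therefore a small expected rise in this assay that stays within the scatter. The estimate for compound 3 is 1200 nM with an expected range from 500 nM to 2900 nM as its bounds.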

Compound 3, half-maximal inhibitory concentration: 1240 nM
Compound 3: the middle estimate sits 1.0-fold (0.01 log units) below what was measured, and the stated range covers the measured number.
By their numbers in this assay, from the lowest: compounds 2 and 3 (each within the scatter of the next); then compound 1.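

In this assay the exchange of 4-chlorobenzyl for 3-chlorobenzyl, on a saturated chain carbon bound to an aromatic nitrogen, can now be read on its own, and it gives a 1.5-fold higher number from compound 2 to compound 3 (0.17 log units; within the scatter) on the shared core. Among the compounds shown here, the two chlorobenzyl groups therefore cannot be told apart on this read-out, whereas the earlier compounds carried this change only together with a second one. For the compounds shown here, compound 3 also gives the first single-place reading of the amine, where dimethylamino in place of 4-methylpiperidin-1-yl on a saturated chain carbon bound to an aromatic carbon gives a 2.3-fold lower number from compound 1 to compound 3 (0.36 log units; beyond the scatter) and so is the only change read here that exceeds the scatter, though nothing at hand explains the size of either step.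

From the compounds shown here alone, the amine step has been read only with 3-chlorobenzyl, so whether it carries over to 4-chlorobenzyl remains open. Also open is how this assay responds to other groups at these two places, such as unsubstituted benzyl or bromobenzyl on the aromatic nitrogen, or morpholine or pyrrolidine in place of the amines shown.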